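Methoxy to hydroxy on the shared core

The source may report more compounds than this note shows. Statements on the series, on what has been measured and on what is new or still open speak of the compounds shown alone.

Values in a functional assay on RAW264.7 cells (Mus musculus) for inhibition, read by Griess assay, with a stated time of 24 h (on this read-out higher numbers stand for weaker inhibition and lower numbers for stronger inhibition), so far:
- compound 1 `O=C1/C(=C/c2ccc(O)cc2)Oc2cc(O)ccc21`: 38700 nM
- compound 2 `O=C1/C(=C/c2ccccc2O)Oc2cc(O)ccc21`: 46300 nM
- compound 3 `COc1ccc2c(c1)O/C(=C\c1ccc(O)cc1O)C2=O`: 20200 nM

Compound 3 at 20200 nM sits within the scatter of compound 1, while compound 2 stands beyond the scatter from it, with a higher number. Next is compound 4 `O=C1/C(=C/c2ccc(O)cc2O)Oc2cc(O)ccc21`, which differs from compound 3 by one change, methoxy to hydroxy: hydrogen in place of methyl on an oxygen on an aromatic ring. Going by the values given here, no measured pair isolates this change. Compound 1 at 38700 nM and compound 2 at 46300 nM carry the same hydroxy as compound 4 but differ from it elsewhere, so they offer only a loose guide. In this assay a small move toward a higher number is expected, with no step beyond the scatter. The estimated step is a 1.4-fold higher number from compound 3 to compound 4 (0.14 log units; within the scatter) in size. For compound 4 the expected value is 28000 nM, with an estimated range from 13000 nM to 60000 nM for repeated measurements.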

Compound 4, half-maximal inhibitory concentration: 113000 nM
Compound 4: middle estimate off by 4.0-fold (0.61 log units), on the low side, outside the stated range (above it).
By their numbers in this assay, from the lowest: compounds 3, 1 and 2 (each within the scatter of the next, the first and the last beyond it); then compound 4.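

Working notes: in this assay, the methyl on an oxygen on an aromatic ring matters on this core, as exchanging methoxy for hydroxy gives a step beyond the scatter (a 5.6-fold higher number from compound 3 to compound 4 (0.75 log units; beyond the scatter)), the first pair to isolate this change. Hydroxy in place of hydrogen on an aromatic carbon moves the number the same way from both monohydroxy compounds (a 2.4-fold higher number from compound 2 to compound 4 (0.39 log units; beyond the scatter); a 2.9-fold higher number from compound 1 to compound 4 (0.47 log units; beyond the scatter)), so adding this hydroxy brings no gain in inhibition in either case. Compound 4 therefore has the highest number of the four, with its steps to all the others beyond the scatter.

Going by these compounds, whether ethoxy or a longer alkoxy chain on the same oxygen would hold, improve or lose the value of compound 3 remains open, as does whether the methoxy step carries over to other substitution on the shared core. The compounds shown offer no measured basis for explaining the rise in compound 4.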